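Taking the methoxy off compound 2

A few compounds are considered here, and "the series" means these few. Any claim that something is new, unique, unknown or untested is made for them only; others in the source may bear on it.

Compound 1 `CC(=O)c1ccc(NC(=O)Cn2nc(-c3ccc(Cl)cc3)nc2N)cc1` gives 8.53%
Compound 2 `COc1ccc(-c2nc3sc(-c4ccccc4)cn3n2)cc1` gives 34%

In a functional assay on SNB-19 cells (Homo sapiens) for inhibition, read by sulforhodamine B assay, with a stated time of 48 h, tested at 10 uM (on this read-out higher numbers stand for more inhibition of growth at the one concentration tested and lower numbers for less inhibition of growth), compound 2 holds the higher of the two numbers, at 34%, and its lead over compound 1 lies beyond the scatter. Compound 3 `c1ccc(-c2nc3sc(-c4ccccc4)cn3n2)cc1` has not yet been measured. It carries hydrogen in place of methoxy on an aromatic carbon, para to a large group (hydrogen in place of methoxy on an aromatic carbon). For the measured compounds named here, no measured pair shows this change, so the evidence for its size is thin. A small fall is expected, a number 6 percentage points lower from compound 2 to compound 3 (within the scatter), which stays within the scatter. The estimated value for compound 3 is 28% (10% to 48%).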

Compound 3, percent growth inhibition at one concentration: 11%
Compound 3: the middle estimate sits 17 percentage points above what was measured; measured number inside the range.
By their numbers in this assay, from the lowest: compounds 1 and 3 (each within the scatter of the next); then compound 2.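

For the compounds shown here, this is the first measured pair at this position, on an aromatic carbon para to a large group. In this assay, hydrogen in place of methoxy gives a number 23 percentage points lower from compound 2 to compound 3 (beyond the scatter), so the methoxy on this shared core is not a neutral passenger. No measurement shown here accounts for the size of this step. From the compounds shown here alone, the result rests on this single pair, so it remains open whether methoxy is special at this position. A hydroxyl, an ethoxy or an amine on the same carbon could keep the number near that of compound 2 or leave it near that of compound 3.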